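Working notes: cytotoxicity limits and compound 4

The source may report more compounds than this note shows. Statements on the series, on what has been measured and on what is new or still open speak of the compounds shown alone.

Compound 1 `Nc1nc(NC2CCCCC2)c2ncn(/C=C3/CC3(CO)CO)c2n1` in an ADME assay on BCBL1 cells (Homo sapiens) for cytotoxicity, with a stated time of 7 days (a higher number here means that more compound is tolerated, a lower number that less compound is tolerated), gives > 20000 nM, which is a limit of the assay.
Compound 2 `CCCSc1nc(N)nc2c1ncn2/C=C1/CC1(CO)CO` in this assay gives > 20000 nM, also a limit.
Compound 3 `CCCCCCOc1nc(N)nc2c1ncn2/C=C1/CC1(CO)CO` in this assay gives > 20000 nM, again a limit.

Compound 3 therefore stands only at a limit, as do the other two values shown (the limit of > 20000 nM in this assay, at which 3 of the 3 values shown sit). The change to compound 4 `CC(C)Nc1nc(N)nc2c1ncn2/C=C1/CC1(CO)CO` is isopropylamino in place of hexyloxy on an aromatic carbon. For the measured compounds named here, the steps that bear on this position are a step that the two limits leave unreadable from compound 1 to compound 3, a step that the two limits leave unreadable from compound 2 to compound 3 and a step that the two limits leave unreadable from compound 1 to compound 2, none of them readable in size. No readable step exists for any exchange at this carbon, so no shift beyond the scatter can be expected. Compound 4 is estimated at 30000 nM, range 12000 nM to 100000 nM, which means an expected step that the limit leaves unreadable from compound 3 to compound 4, most likely reported again as a limit.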

Compound 4, half-maximal cytotoxic concentration: > 20000 nM
Compound 4: only a limit was reported; the forecaster's own chance of this, stated with the estimate: 85%; the middle value lies beyond the limit too.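

Compound 4 adds no readable step against compound 1, compound 2 or compound 3, because all four stand at one limit: the limit of > 20000 nM in this assay, at which 4 of the 4 values shown sit.

The compounds shown leave open whether any exchange at this aromatic carbon shifts the half-maximal cytotoxic concentration in this assay at all.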